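The compounds below may be only part of what the source reports. "The series", "measured", "known", "first", "only" and "open" are said of these compounds alone.

Measured in an ADME assay on MT4 cells (Homo sapiens) for cytotoxicity, read by MTT assay; a lower number here means that less compound is tolerated, a higher number that more compound is tolerated:
- Compound 1 `O=C1c2ccccc2C(=O)N1CCOC(=S)N(C(=O)c1ccc(F)c(F)c1)c1ccc(Cl)cc1`: 52000 nM
- Compound 2 `O=C1c2ccccc2C(=O)N1CCOC(=S)N(C(=O)c1ccc(Cl)c(Cl)c1)c1ccc(Cl)cc1`: 35000 nM

Going by the values given here, only two compounds have been measured in this assay, and their values lie within the scatter of each other, so neither can be ranked above the other. Compound 2 therefore stands level with compound 1. The next compound to be tested is compound 3 `O=C1c2ccccc2C(=O)N1CCOC(=S)N(C(=O)c1cc(Cl)cc(Cl)c1)c1ccc(Cl)cc1`, which has the same atoms as compound 2, joined differently: 3,5-dichlorophenyl in place of 3,4-dichlorophenyl on a carbonyl carbon. In short, 3,5-dichlorophenyl stands in place of 3,4-dichlorophenyl on a carbonyl carbon.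

Just one measured step bears on this group, a 1.5-fold lower number from compound 1 to compound 2 (0.17 log units; within the scatter). Among the compounds with values here, that step exchanged the halogens and did not move them, so it is only indirect evidence, and no measured step shows what moving a chlorine does. Even so, the one change made on this group stayed within the scatter, so no shift in either direction is expected beyond it. The step expected is no change at the digits printed from compound 2 to compound 3 (within the scatter). For compound 3 the estimated value is 35000 nM, with an expected range from 16000 nM to 75000 nM.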

Compound 3, half-maximal cytotoxic concentration: 32000 nM
Estimate against measurement, compound 3: 1.1-fold (0.04 log units) above; the measured number falls inside the stated range.
By their numbers in this assay, from the lowest: compounds 3, 2 and 1 (each within the scatter of the next).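

In this assay, the exchange on the carbonyl carbon now includes a change in how the same atoms are joined, which the earlier step did not cover: 3,5-dichlorophenyl in place of 3,4-dichlorophenyl gives a direct reading (a 1.1-fold lower number from compound 2 to compound 3 (0.04 log units; within the scatter)). Replacing 3,4-difluorophenyl with 3,5-dichlorophenyl, which alters both the halogen and its placing, also stays inside the usual spread (a 1.6-fold lower number from compound 1 to compound 3 (0.21 log units; within the scatter)), so the three groups at this place, on a carbonyl carbon whose other neighbour is an amide-type nitrogen, cannot be told apart by this read-out. Nothing at hand explains these values.

On these data alone, all three compounds carry a dihalogenated phenyl at this place and share the rest of their structure, so it remains open whether any other group here would give a number in this assay beyond the scatter of these three. A phenyl bearing a carboxylic acid or an amine, or a longer chain in place of the phenyl, could settle whether this tolerance extends past halogen-substituted rings.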